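Dichlorobenzyl positional swap within the thiourea series

The source may report more compounds than this note shows. Statements on the series, on what has been measured and on what is new or still open speak of the compounds shown alone.

Three members of the series carry measurements in a functional assay on MNK45 cells (Homo sapiens) for inhibition, read by MTT assay, with a stated time of 48 h; on this read-out higher numbers stand for weaker inhibition and lower numbers for stronger inhibition. Compound 1 `Cc1ccc(NC(=S)NC(=O)c2ccc(OCc3ccc(Cl)cc3Cl)cc2)cc1-c1nc2ccccc2[nH]1` gives 5300 nM in this assay. Compound 2 `O=C(NC(=S)Nc1ccc(Cl)c(-c2nc3ccccc3[nH]2)c1)c1ccc(OCc2ccc(C(F)(F)F)cc2)cc1` gives 7830 nM. Compound 3 `O=C(NC(=S)Nc1ccc(Cl)c(-c2nc3ccccc3[nH]2)c1)c1ccc(OCc2ccc(Cl)c(Cl)c2)cc1` gives 4600 nM, the smallest figure of the three, yet compound 1 and compound 2 both sit within the scatter of compound 3, so no ranking among them is secure.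

Compound 4 `O=C(NC(=S)Nc1ccc(Cl)c(-c2nc3ccccc3[nH]2)c1)c1ccc(OCc2ccc(Cl)cc2Cl)cc1` differs from compound 3 only in the group on the benzylic carbon: 2,4-dichlorophenyl in place of 3,4-dichlorophenyl on a saturated chain carbon bound to an oxygen on an aromatic ring. Among the measured compounds shown here, the single measured step at this position, a 1.7-fold lower number from compound 2 to compound 3 (0.23 log units; within the scatter), stayed within the scatter. For the measured compounds named here, compound 1 also carries the 2,4-dichlorophenyl group at this position, on a differently substituted core, and its value in this assay and that of compound 3 lie within the scatter of each other; no step between them is computed. Nothing therefore points to a shift beyond the scatter, and the step of a 1.1-fold higher number from compound 3 to compound 4 (0.04 log units; within the scatter) is expected to be flat. Compound 4 is estimated at 5000 nM in this assay, in the range 2500 nM to 10000 nM.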

Compound 4, half-maximal inhibitory concentration: 3750 nM
Compound 4: middle estimate off by 1.3-fold (0.12 log units), on the high side; low and high end bracket the measured number.
By their numbers in this assay, from the lowest: compounds 4, 3, 1 and 2 (each within the scatter of the next, the first and the last beyond it).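

In this assay, 2,4-dichlorophenyl in place of 3,4-dichlorophenyl, the same atoms joined differently, gives a 1.2-fold lower number from compound 3 to compound 4 (0.09 log units; within the scatter) and so shows no readable difference between these two dichlorophenyl groups on this saturated chain carbon. Against 4-(trifluoromethyl)phenyl, however, 2,4-dichlorophenyl gives a 2.1-fold lower number from compound 2 to compound 4 (0.32 log units; beyond the scatter) as the first step at this position to pass the scatter, though only modestly and with compound 3 still within the scatter of both neighbours. With 2,4-dichlorophenyl held constant, chloro in place of methyl on an aromatic carbon gives a 1.4-fold lower number from compound 1 to compound 4 (0.15 log units; within the scatter) and is flat as well.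

As far as these compounds go, it remains open whether a single chloro, a methoxy or an amine on this phenyl ring would move the number further, and whether a longer chain in place of the benzylic carbon would be tolerated. Nothing available bears on why these numbers fall as they do.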